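Aryl substituent variation on the shared core

This account rests on a few compounds, and the source may have more. Where it says the series, first, only, none or still open, it means among the compounds named here.

compound 1 `CCCS(=O)(=O)Nc1ccc(F)c(C(=O)c2n[nH]c3ncc(-c4ccccc4)cc23)c1F`: 2.4%
compound 2 `CCCS(=O)(=O)Nc1ccc(F)c(C(=O)c2n[nH]c3ncc(-c4ccccc4C)cc23)c1F`: 7%
compound 3 `CCCS(=O)(=O)Nc1ccc(F)c(C(=O)c2n[nH]c3ncc(-c4ccccc4OC)cc23)c1F`: 1.9%

In an assay for binding affinity to dual specificity mitogen-activated protein kinase kinase 4 (Homo sapiens), read by KINOMEscan, tested at 100 nM (a higher number here means a weaker effect of the compound at the concentration tested, a lower number a stronger effect), compound 3 holds the lowest of the three numbers, yet all three sit within the scatter of one another: the step of a number 0.5 percentage points lower from compound 1 to compound 3 (within the scatter) and the step of a number 5.1 percentage points lower from compound 2 to compound 3 (within the scatter) are both small. Compound 4 `CCCS(=O)(=O)Nc1ccc(F)c(C(=O)c2n[nH]c3ncc(-c4cccc(O)c4)cc23)c1F` is not yet measured. It differs from compound 3 by 3-hydroxyphenyl in place of 2-methoxyphenyl on an aromatic carbon. Among the compounds with values here, no measured step exchanges a methoxy for a hydroxyl or moves a substituent around the phenyl; the two steps that end at compound 3 concern methoxy in place of hydrogen and methoxy in place of methyl, and neither left the scatter. From this, compound 4 is expected to show no step beyond the scatter, a number 1.6 percentage points higher from compound 3 to compound 4 (within the scatter). The estimate for compound 4 is 3.5%, within 0.5% to 15%.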

Compound 4, a percentage reported as activity, at one concentration (the size of the read-out at that concentration, not a potency): 2.2%
The estimate for compound 4 lay 1.3 percentage points above the measured number; low and high end bracket the measured number.
By their numbers in this assay, from the lowest: compounds 3, 4, 1 and 2 (each within the scatter of the next).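

In this assay, within the data shown here, the hydroxy of compound 4 is the first hydrogen-bond donor on this phenyl, and adding it to compound 1 gives only a small step (a number 0.2 percentage points lower from compound 1 to compound 4 (within the scatter)). Moving to the 3-hydroxyphenyl from the 2-methoxyphenyl of compound 3 (a number 0.3 percentage points higher from compound 3 to compound 4 (within the scatter)) or the 2-methylphenyl of compound 2 (a number 4.8 percentage points lower from compound 2 to compound 4 (within the scatter)) also stays small, so a change in both group and ring position leaves the read-out unchanged within the scatter. No measured evidence bears on this result. Still open, going by these compounds, is whether an amine, a carboxylic acid or a longer chain on this phenyl would produce a step beyond the scatter.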